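Working notes: cytotoxicity across compounds 1 to 4

This account rests on a few compounds, and the source may have more. Where it says the series, first, only, none or still open, it means among the compounds named here.

Measured so far:
- compound 1 `O=c1nc(N2CCC(CCO)CC2)sc2c([N+](=O)[O-])cc(C(F)(F)F)cc12`: in a toxicity assay on HeLa cells (Homo sapiens) for cytotoxicity, read by colorimetric assay, with a stated time of 72 h (on this read-out higher numbers stand for lower toxicity in this test and lower numbers for higher toxicity in this test), compound 1 gives 91500 nM
- compound 2 `O=c1nc(N2CC[C@@H](c3ccc(F)cc3)[C@H](CO)C2)sc2c([N+](=O)[O-])cc(C(F)(F)F)cc12`: in this assay compound 2 gives 35800 nM
- compound 3 `N#Cc1cccc(N2CCN(c3nc(=O)c4cc(C(F)(F)F)cc([N+](=O)[O-])c4s3)CC2)c1`: in this assay compound 3 reaches only a limit, > 108000 nM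

Compound 3 therefore stands at the top of the set on the numbers shown; its value is a limit of the assay and not a measured number, as given by the limit of > 108000 nM in this assay, at which 1 of the 3 values shown sits. Compound 1 and compound 2 both return measured numbers, and the number for compound 2 is lower than the number for compound 1. Among the measured compounds shown here, no step between compounds differing in one place is available, so no measured step size can be quoted.

Compound 4 `O=C(CN1CCN(c2nc(=O)c3cc(C(F)(F)F)cc([N+](=O)[O-])c3s2)CC1)N1CCCC1` carries the shared core with the piperazine substituent exchanged: ((pyrrolidin-1-yl)carbonyl)methyl in place of 3-cyanophenyl on an amine nitrogen in a ring. For the measured compounds named here, nothing among the measured compounds tests this change, so the expectation for compound 4 is anchored on compound 3 at its limit > 108000 nM and carries wide uncertainty; the step from compound 3 to compound 4 is expected to be small, an at least 1.1-fold lower number from compound 3 to compound 4 (0.05 log units; that floor lies within the scatter), and may well end at the limit again. For compound 4 the estimate in this assay is 95000 nM, within a range from 40000 nM to 200000 nM.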

Compound 4, half-maximal cytotoxic concentration: > 106000 nM
Compound 4 was reported as a limit; the forecaster's own chance of this, stated with the estimate: 55%; at least 1.1-fold (0.04 log units) between middle value and limit.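

Compound 4 also reaches only a limit, not a measured number, in this assay: the limit of > 106000 nM in this assay, at which 1 of the 4 values shown sits. Compound 3 likewise stands at a limit: the limit of > 108000 nM in this assay, at which 1 of the 4 values shown sits. With both compounds at limits, the step between them cannot be read. The compounds shown leave open what exchanging 3-cyanophenyl for ((pyrrolidin-1-yl)carbonyl)methyl does to the number in this read-out.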